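Amide-nitrogen substituent in a TRPM8 agonist series

A few compounds are considered here, and "the series" means these few. Any claim that something is new, unique, unknown or untested is made for them only; others in the source may bear on it.

Measured so far:
compound 1 `Cc1ccc(OCC(=O)N(Cc2cccs2)c2cnn(C)c2)cc1` — 63000 nM
compound 2 `Cc1ccc(OCC(=O)N(Cc2cccs2)c2ccn(C)n2)cc1` — 855 nM
compound 3 `Cc1ccc(OCC(=O)N(Cc2cccs2)c2ccccn2)cc1` — 200 nM

All three share the same core and differ only in the group on the amide-type nitrogen. In an assay on HEK293 cells for agonist activity at transient receptor potential cation channel subfamily M member 8 (Homo sapiens), read by fluorescence and calcium flux, with a stated time of 15 min (on this read-out higher numbers stand for an effect only at larger amounts of compound and lower numbers for an effect already at smaller amounts), compound 3 gives 200 nM, the lowest of the three numbers; its nearest neighbour is compound 2 with a 4.3-fold lower number from compound 2 to compound 3 (0.63 log units; beyond the scatter), and the furthest is compound 1 with a 320-fold lower number from compound 1 to compound 3 (2.50 log units; beyond the scatter). Between the two pyrazole isomers the step is a 74-fold lower number from compound 1 to compound 2 (1.87 log units; beyond the scatter). Every change at this nitrogen so far has moved the read-out beyond the scatter, so the position is clearly sensitive.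

Compound 4 `Cc1ccc(OCC(=O)N(O)Cc2cccs2)cc1` is not yet measured. Its difference from compound 3 is hydroxy in place of pyridin-2-yl on an amide-type nitrogen. Among the compounds with values here, no measured step covers this exact change; the three steps only show that swapping one aromatic ring for another at the amide nitrogen shifts the number by large amounts, and that the ring in compound 3 gives the lowest value seen. Removing the ring entirely is a larger departure than any measured step, so a large shift toward a higher number is expected, in a 100-fold higher number from compound 3 to compound 4 (2.00 log units; beyond the scatter). For compound 4 the expected value in this assay is 20000 nM, with a range of 3000 nM to 100000 nM.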

Compound 4, half-maximal effective concentration: 8000 nM
Beside the measured number, compound 4's estimate is 2.5-fold (0.40 log units) above it; low and high end bracket the measured number.
By their numbers in this assay, from the lowest: compound 3; then compound 2; then compound 4; then compound 1.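

In this assay the ring on the amide-type nitrogen proves not to be required for a response, since hydroxy, with no ring and a single heavy atom, lands inside the span of the three aromatic groups rather than outside it. The loss against the best ring is large, at a 40-fold higher number from compound 3 to compound 4 (1.60 log units; beyond the scatter) and, against the 1-methyl-1H-pyrazol-3-yl group, modest, at a 9.4-fold higher number from compound 2 to compound 4 (0.97 log units; beyond the scatter) but the 1-methyl-1H-pyrazol-4-yl group goes against any simple rule that a ring helps here, as its removal gives a 7.9-fold lower number from compound 1 to compound 4 (0.90 log units; beyond the scatter) and so that ring gives a higher number than no ring at all. No data on hand explain this order of the four groups at the position.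

Still open, on these data alone, is whether methoxy or methyl on the same nitrogen would track hydroxy, which would separate the loss of the ring from the hydrogen-bond donor that enters with hydroxy. Also open, as far as these compounds go, is whether a phenyl ring or a pyridin-3-yl ring would match pyridin-2-yl, and whether an amine at this nitrogen would fit anywhere in the present order.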